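The source may hold more compounds than are shown below. What is called first, only, known or untested is meant among the compounds shown, and "the series" means these compounds.

Measured so far in a functional assay on HL-60 cells (Homo sapiens) for cytotoxicity, read by luminescence and CellTiter-Glo, with a stated time of 3 days; on this read-out lower numbers stand for stronger inhibition and higher numbers for weaker inhibition:
compound 1 (`N#Cc1cccc(NC(=O)c2cc(F)ccc2O)c1`): 7750 nM
compound 2 (`O=C(Nc1ccc(C(F)(F)F)cc1)c1cc(Cl)c(-c2ccccc2)cc1O`): 490 nM

Of these two numbers, compound 1 holds the higher at 7750 nM, and compound 2 stands lower at 490 nM, a gap beyond the usual scatter. Among the compounds with values here, the two compounds differ in more than one place, so no single structural step between measured compounds is available as a guide.

Compound 3 (`O=C(Nc1cccc(OC(F)(F)F)c1)c1cc(F)ccc1O`) has not yet been measured. It keeps the core of compound 1 and makes one exchange: trifluoromethoxy in place of cyano on an aromatic carbon, meta to a large group (trifluoromethoxy in place of cyano on an aromatic carbon).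

Within the data shown here, with no measured pair showing this exchange, the expectation in this assay is only tentative: a modest move toward a lower number, which may not clear the scatter. Among the measured compounds shown here, the sole support is that compound 2, which bears a trifluoromethyl group, gives 490 nM, although it also differs from compound 1 elsewhere. The expected change is a 3.1-fold lower number from compound 1 to compound 3 (0.49 log units; beyond the scatter). For compound 3 the estimated value is 2500 nM, with an expected range from 700 nM to 9000 nM.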

Compound 3, half-maximal inhibitory concentration: 730 nM
Compound 3: middle estimate off by 3.4-fold (0.53 log units), on the high side; the measured number falls inside the stated range.
By their numbers in this assay, from the lowest: compounds 2 and 3 (each within the scatter of the next); then compound 1.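

In this assay, trifluoromethoxy in place of cyano on an aromatic carbon, meta to a large group, brings an 11-fold lower number from compound 1 to compound 3 (1.03 log units; beyond the scatter), with the rest of compound 1 left as it stands. Within the data shown here, this is the first comparison that isolates a single place, and it shows that the number responds strongly to the group held there, which the gap between the earlier compounds, differing in more than one place, could not show. The exchange raises the group from 2 to 5 heavy atoms while leaving the counts of hydrogen-bond donors and acceptors and the net charge as they were, yet nothing measured here accounts for the size of the step.

The compounds shown leave open how far the step is tied to trifluoromethoxy itself, since a single exchange cannot say whether a methoxy group, an amine or a carboxylic acid on the same carbon would move the number in the same direction. They also leave open whether the same exchange would carry a comparable step on a core other than that of compound 1.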